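Bromo to fluoro in a small halogen series

The compounds below may be only part of what the source reports. "The series", "measured", "known", "first", "only" and "open" are said of these compounds alone.

In a functional assay on NCI-H292 cells (Homo sapiens) for cytotoxicity, read by MTT assay, with a stated time of 72 h, tested at 5 ug/mL (a lower number here means less inhibition of growth, a higher number more inhibition of growth at the concentration tested), compound 2 `O=C1NC(=S)/C(=C/c2ccc(Br)cc2)S1` gives 16.6% and sits lowest of the two measured, with compound 1 `O=C1NC(=S)/C(=C/c2ccc(Cl)cc2)S1` at 35.8% above it. Compound 3 `O=C1NC(=S)/C(=C/c2ccc(F)cc2)S1` differs from compound 2 by fluoro in place of bromo on an aromatic carbon and carries fluoro in place of bromo on an aromatic carbon. Among the measured compounds shown here, only one measured step bears on this, the modest a number 19.2 percentage points lower from compound 1 to compound 2 (beyond the scatter) on bromo in place of chloro. For the measured compounds named here, no fluoro compound has a reading yet, so the direction rests on that single pair. The estimated change is a number 11.4 percentage points higher from compound 2 to compound 3 (beyond the scatter) and is expected to be upward but smaller than that step. Compound 3 is expected at 28% (estimated range 12% to 46%).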

Compound 3, percent growth inhibition at one concentration: 31.6%
Compound 3: the middle estimate sits 3.6 percentage points below what was measured; low and high end bracket the measured number.
By their numbers in this assay, from the lowest: compound 2; then compounds 3 and 1 (each within the scatter of the next).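

In this assay, at this position on the aromatic ring, fluoro in place of bromo gives a number 15 percentage points higher from compound 2 to compound 3 (beyond the scatter) and shows that the low reading of compound 2 does not extend to the fluoro compound. Fluoro in place of chloro gives a number 4.2 percentage points lower from compound 1 to compound 3 (within the scatter) and leaves these two halogens indistinguishable here, so among the three only bromo stands apart. Nothing available explains why bromo differs from the other two halogens. On these data alone, whether an amine or a methoxy group at this position would read like the halogens remains open.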